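Methyl ester of compound 2: cytotoxicity outlook

The compounds below may be only part of what the source reports. "The series", "measured", "known", "first", "only" and "open" are said of these compounds alone.

Compound 2 `COC(=O)c1cc(O)cc(OC)c1Oc1c(Cl)c(C)c(Cl)c(O)c1C(=O)O` is known in an ADME assay on Caco-2 cells (Homo sapiens) for cytotoxicity, read by MTT assay, with a stated time of 72 h (a higher number here means that more compound is tolerated, a lower number that less compound is tolerated), only as a limit, where compound 2 gives > 800000 nM. Compound 1 `CC1(C)CCc2cc(CC3OC(=O)C(O)=C3c3ccc(O)cc3)ccc2O1` likewise reaches only a limit, with compound 1 at > 800000 nM in this assay. Both values thus sit at the limit of > 800000 nM in this assay, at which 2 of the 2 values shown sit. Compound 3 `COC(=O)c1cc(O)cc(OC)c1Oc1c(Cl)c(C)c(Cl)c(O)c1C(=O)OC` has not yet been measured; it differs from compound 2 by methyl in place of hydrogen on an oxygen next to a carbonyl group. Among the compounds with values here, no step between measured compounds is available to guide the size of this change. The step expected here is a number no higher from compound 2 to compound 3 (the limit leaves the size open), none beyond the scatter. Compound 3 is therefore estimated at 800000 nM, within 400000 nM to 1600000 nM, most probably again reported only as a limit.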

Compound 3, half-maximal cytotoxic concentration: > 800000 nM
Compound 3: no number, only a limit (the forecaster's own chance of this, stated with the estimate: 85%); the middle value sits exactly at the limit.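

In this assay compound 2 and compound 3 stand only as limits, and no step can be read between them. The compounds shown leave open what concentration would reach the half-maximal cytotoxic read-out for any of them: the limit of > 800000 nM in this assay, at which 3 of the 3 values shown sit.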